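The source may hold more compounds than are shown below. What is called first, only, known or untested is meant among the compounds shown, and "the series" means these compounds.

Values in a physicochemical assay for solubility (on this read-out lower numbers stand for lower solubility and higher numbers for higher solubility), so far:

- Compound 1 `O=C(CN1CC[C@@H](NC(=O)c2ccc(Cl)s2)C1)Nc1ccc(-n2ccccc2=O)cc1F` gives 197 ug/mL
- Compound 2 `O=C(CN1CC[C@H](NC(=O)c2ccc(Cl)s2)C1)Nc1ccc(-n2ccccc2=O)cc1F` gives 166 ug/mL

Within the data shown here, compound 1 stands level with compound 2, the only other measured compound, since their two values lie within the scatter of each other. The next compound to be read in this assay is compound 3 `O=C(CN1C[C@H](NC(=O)c2ccc(Cl)s2)[C@@H](O)C1)Nc1ccc(-n2ccccc2=O)cc1F`, which has not yet been measured. It departs from compound 1 as follows: hydroxy in place of hydrogen on a saturated ring carbon. In words, a hydroxy takes the place of hydrogen on a saturated ring carbon.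

Among the measured compounds shown here, only one measured step is at hand, a 1.2-fold lower number from compound 1 to compound 2 (0.07 log units; within the scatter), and it comes with the fact that compounds 1 and 2 differ only in the configuration as drawn. That step therefore speaks to configuration alone, and its size stays within the scatter. For the measured compounds named here, no measured pair shows what a hydroxy in place of hydrogen does in this assay, so no direction can be drawn from the data, and the expectation stays close to compound 1 at 197 ug/mL with a wide margin. The expected change, no larger than the scatter, is a 1.0-fold higher number from compound 1 to compound 3 (0.01 log units; within the scatter). For compound 3 the estimated value is 200 ug/mL, with an expected range from 80 ug/mL to 500 ug/mL.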

Compound 3, solubility: 516000 ug/mL
Beside the measured number, compound 3's estimate is 2600-fold (3.41 log units) below it, and the stated range ends below it.
By their numbers in this assay, from the lowest: compounds 2 and 1 (each within the scatter of the next); then compound 3.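

In this assay the saturated ring carbon that takes the hydroxy proves to be a place where a single change goes with a large step, namely a 2600-fold higher number from compound 1 to compound 3 (3.42 log units; beyond the scatter) at this position. The earlier step of a 1.2-fold lower number from compound 1 to compound 2 (0.07 log units; within the scatter) spoke to configuration alone and stayed within the scatter, so it gave no sign of what a substitution on this ring carbon, two ring bonds from the ring nitrogen, would do on this read-out. Nothing in the data shown accounts for a step of this size.

From the compounds shown here alone, what stays open is whether the step belongs to the hydroxy itself or would also appear with another group on this ring carbon, such as methoxy, fluorine or an amine. Among these compounds, also open is whether the configuration drawn at the hydroxy-bearing carbon matters and whether a hydroxy on another ring carbon would give a similar step, as the finding rests on the single pair of compound 1 and compound 3.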